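Bromo to hydrogen, second instance in the series

A few compounds are considered here, and "the series" means these few. Any claim that something is new, unique, unknown or untested is made for them only; others in the source may bear on it.

Compound 1 `O=C(CCl)Nc1ccc(SCC(=O)Nc2ccc(Br)cn2)cc1` gives 530 nM in a functional assay on NCI-H460 cells (Homo sapiens) for antiproliferative activity, read by MTT assay, with a stated time of 48 h; on this read-out higher numbers stand for weaker inhibition and lower numbers for stronger inhibition. Compound 2 `O=C(CCl)Nc1ccc(SCC(=O)Nc2ccccn2)cc1` differs from it by hydrogen in place of bromo on an aromatic carbon and in this assay compound 2 gives 11900 nM, a step of a 22-fold higher number from compound 1 to compound 2 (1.35 log units; beyond the scatter). Compound 3 `O=C(CCCl)Nc1ccc(SCC(=O)Nc2ccc(Br)cn2)cc1` carries a different core, (chloromethyl in place of chloro on a saturated chain carbon bound to a carbonyl carbon); in this assay compound 3 gives 1600 nM, a step of a 3.0-fold higher number from compound 1 to compound 3 (0.48 log units; beyond the scatter). Compound 4 `O=C(CCCl)Nc1ccc(SCC(=O)Nc2ccccn2)cc1` is not yet measured; from compound 3 it differs by hydrogen in place of bromo on an aromatic carbon, the same change as that from compound 1 to compound 2, at an identically described place. For compound 4 the expected step is a 19-fold higher number from compound 3 to compound 4 (1.27 log units; beyond the scatter) in this assay, of similar size to the earlier instance, because a 22-fold higher number from compound 1 to compound 2 (1.35 log units; beyond the scatter) was seen there on a core differing only in the chloro chain. Compound 4 is therefore estimated at 30000 nM in this assay, between 10000 nM and 90000 nM.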

Compound 4, half-maximal inhibitory concentration: 65400 nM
Estimate against measurement, compound 4: 2.2-fold (0.34 log units) below; the measured number falls inside the stated range.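

Notes on the series: in this assay hydrogen in place of bromo gives a 41-fold higher number from compound 3 to compound 4 (1.61 log units; beyond the scatter) and the change carries over from one core to the other without a difference beyond the scatter: the same change on two cores in this assay, a 22-fold higher number (1.35 log units; beyond the scatter) from compound 1 to compound 2 and a 41-fold higher number (1.61 log units; beyond the scatter) from compound 3 to compound 4, 1.8-fold (0.26 log units) apart, within the scatter of two such steps.
Chloromethyl in place of chloro gives a 5.5-fold higher number from compound 2 to compound 4 (0.74 log units; beyond the scatter) and likewise holds on both cores: the same change on two cores in this assay, a 3.0-fold higher number (0.48 log units; beyond the scatter) from compound 1 to compound 3 and a 5.5-fold higher number (0.74 log units; beyond the scatter) from compound 2 to compound 4, 1.8-fold (0.26 log units) apart, within the scatter of two such steps.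
The two changes therefore behave consistently across these four compounds, but this rests on a single pair of cores in one assay and does not show that either step would hold on any other core or explain why the steps have this size.

Still open, on these data alone, is whether chloro or methyl in place of the bromo would keep the number of compound 1 or compound 3. Also open, as far as these compounds go, is how an amine in place of the chain chloro would behave.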